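The compounds below may be only part of what the source reports. "The series", "measured", "known", "first", "only" and "open" are said of these compounds alone.

Measured compounds:
Compound 1 `C=C(C)[C@H]1CC=C(C)[C@@]2(O)[C@@H]1[C@H](c1ccc(Cl)cc1Cl)O[C@@H]2C(=O)OCC`: 3000 nM
Compound 2 `C=C(C)[C@H]1CC=C(C)[C@@]2(O)[C@@H]1[C@H](c1ccccc1Br)O[C@@H]2C(=O)OCC`: 20000 nM
Compound 3 `C=C(C)[C@H]1CC(=O)C(C)=C2[C@@H](C(=O)OCC)O[C@@H](c3ccccc3Br)[C@@H]21`: 70000 nM

All three were run in a functional assay on KB3 cells (Homo sapiens) for antiproliferative activity, read by MTT assay, with a stated time of 96 h; a lower number here means a stronger inhibitor, a higher number a weaker inhibitor. Compound 1 `C=C(C)[C@H]1CC=C(C)[C@@]2(O)[C@@H]1[C@H](c1ccc(Cl)cc1Cl)O[C@@H]2C(=O)OCC` gives 3000 nM in this assay, compound 2 `C=C(C)[C@H]1CC=C(C)[C@@]2(O)[C@@H]1[C@H](c1ccccc1Br)O[C@@H]2C(=O)OCC` gives 20000 nM, and compound 3 `C=C(C)[C@H]1CC(=O)C(C)=C2[C@@H](C(=O)OCC)O[C@@H](c3ccccc3Br)[C@@H]21` gives 70000 nM, the highest of the three numbers. Compounds 1 and 2 share a core and differ in one place: 2,4-dichlorophenyl in place of 2-bromophenyl on a saturated ring carbon. That change made a 6.7-fold lower number from compound 2 to compound 1 (0.82 log units; beyond the scatter).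

Compound 3 has a different core from compound 2; the difference between the two cores is not broken down here. What can be said is that compound 3 sits above compound 2 by a margin beyond the scatter, so the core of compound 3 reads as the weaker of the two on the 2-bromophenyl compounds.

Compound 4 `C=C(C)[C@H]1CC(=O)C(C)=C2[C@@H](C(=O)OCC)O[C@@H](c3ccc(Cl)cc3Cl)[C@@H]21` is not yet measured. It differs from compound 3 in one place: 2,4-dichlorophenyl in place of 2-bromophenyl on a saturated ring carbon. Going by the values given here, this is the same kind of change as the one from compound 2 to compound 1, though the surroundings are not identical: in the core of compound 2 the position is also two ring bonds from the ring atom that bears a fused ring and two ring bonds from the ring atom that bears a hydroxy group, which is not the case in the core of compound 3.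

Among the compounds with values here, on the core of compound 3 the step is expected to be a 5.8-fold lower number from compound 3 to compound 4 (0.77 log units; beyond the scatter), because the same change gave a 6.7-fold lower number from compound 2 to compound 1 (0.82 log units; beyond the scatter) on the other core; a somewhat smaller move is allowed for, since only one prior instance exists and the cores differ. Compound 4 is therefore estimated at 12000 nM in this assay, within 4000 nM to 40000 nM.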

Compound 4, half-maximal inhibitory concentration: 3000 nM
Beside the measured number, compound 4's estimate is 4.0-fold (0.60 log units) above it, outside the stated range (below it).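

In this assay, 2,4-dichlorophenyl in place of 2-bromophenyl gave a 23-fold lower number from compound 3 to compound 4 (1.37 log units; beyond the scatter), so the direction of this change carries from one core to the other, while its size does not: the same change on two cores in this assay, a 6.7-fold lower number (0.82 log units; beyond the scatter) from compound 2 to compound 1 and a 23-fold lower number (1.37 log units; beyond the scatter) from compound 3 to compound 4, 3.5-fold (0.54 log units) apart, beyond the scatter of two such steps

A step read on one core is therefore a guide to direction in this series, not a reliable figure for size on the other. With a single pair on each core, the data do not show which structural difference between the cores goes with the gap, or whether a third core would follow either step. The change also removes 2-bromophenyl and brings in 2,4-dichlorophenyl as one swap, so it does not show what each halogen contributes on its own.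

A plain phenyl, a 2-chlorophenyl or a 4-chlorophenyl on both cores would help to separate these contributions and show whether the gap between the steps persists. The compounds shown also leave open how the series responds when the ethoxycarbonyl group gives way to a carboxylic acid or an amide, since that group is the same in all four.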